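The source may report more compounds than this note shows. Statements on the series, on what has been measured and on what is new or still open speak of the compounds shown alone.

In a functional assay on CCRF-CEM cells (Homo sapiens) for inhibition, read by MTT assay, with a stated time of 72 h (on this read-out higher numbers stand for weaker inhibition and lower numbers for stronger inhibition), compound 1 `COc1cc(-c2c(-c3ccc4cc[nH]c4c3)c(=O)c2=O)cc(OC)c1OC` gives 6.6 nM and compound 2 `COc1ccc(-c2c(-c3cc(OC)c(OC)c(OC)c3)c(=O)c2=O)cc1O` gives 1.7 nM, so compound 2 holds the lower of the two numbers. Compound 3 `COc1ccc(-c2c(-c3cc(OC)c(OC)c(OC)c3)c(=O)c2=O)cc1` is compound 2 with one change: hydrogen in place of hydroxy on an aromatic carbon. This is hydrogen in place of hydroxy on an aromatic carbon, which turns 3-hydroxy-4-methoxyphenyl into 4-methoxyphenyl. Within the data shown here, only one measured step bears on this: a 3.9-fold lower number from compound 1 to compound 2 (0.59 log units; beyond the scatter), a modest step that came with 3-hydroxy-4-methoxyphenyl in place of 1H-indol-6-yl. That step swaps a whole group, so it does not test the hydroxy alone, and the size of the new step remains uncertain. A modest move towards a higher number in this assay is expected. The expected step is a 5.3-fold higher number from compound 2 to compound 3 (0.72 log units; beyond the scatter). For compound 3 the estimated value is 9 nM, with an expected range from 2.5 nM to 40 nM.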

Compound 3, half-maximal inhibitory concentration: 16 nM
The estimate for compound 3 lay 1.8-fold (0.25 log units) below the measured number; low and high end bracket the measured number.
By their numbers in this assay, from the lowest: compound 2; then compound 1; then compound 3.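

Taking away the hydroxy and changing nothing else gives a 9.4-fold higher number from compound 2 to compound 3 (0.97 log units; beyond the scatter) in this assay and so isolates this one group, which the earlier swap of a whole ring could not do. The 4-methoxyphenyl ring also compares poorly with the 1H-indol-6-yl ring, with a 2.4-fold higher number from compound 1 to compound 3 (0.38 log units; beyond the scatter) on this read-out, so 3-hydroxy-4-methoxyphenyl gives the lower number than the indole ring only while the hydroxy is present. Nothing measured here explains why this group makes such a difference.

From the compounds shown here alone, it remains open whether another group at this place, such as an amine or a fluorine, would match the hydroxy or whether only the hydroxy gives this low number. The compounds shown also leave open whether removing the hydroxy would cost as much on a ring without the methoxy group it sits ortho to.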